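The compounds below may be only part of what the source reports. "The series", "measured", "known", "first", "only" and "open" are said of these compounds alone.

Measured compounds:
- Compound 1 `COc1ccc(Cl)cc1N1CCN(CCNC(=O)c2cc3ccccc3o2)CC1`: 2340 nM
- Compound 2 `COc1ccc(Cl)cc1N1CCN(CCNC(=O)c2cc3ccccc3oc2=O)CC1`: 49 nM
- Compound 3 `Cc1ccc(N2CCN(CCNC(=O)c3ccncc3)CC2)c(C)c1`: 85.1 nM

In a functional assay for antagonist activity at Adrenergic receptor alpha-1 (Rattus norvegicus) (a higher number here means weaker binding, a lower number tighter binding), compound 2 gives 49 nM, the lowest of the three numbers. Compound 3 gives 85.1 nM, which lies within the usual scatter of that value, so the two cannot be ranked against each other. Compound 1 gives 2340 nM, a gap far beyond the scatter.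

Compound 4 `COc1ccc(N2CCN(CCNC(=O)c3cc4ccccc4oc3=O)CC2)cc1` has not yet been measured. It differs from compound 2 in one place: 4-methoxyphenyl in place of 5-chloro-2-methoxyphenyl on an amine nitrogen in a ring. Going by the values given here, no measured pair shows this change, so its effect has to be guessed from the three values alone. The step from compound 2 to compound 4 is expected to be a 10-fold higher number from compound 2 to compound 4 (1.01 log units; beyond the scatter), towards a weaker result. The expected value for compound 4 in this assay is 500 nM, within a range of 100 nM to 3000 nM.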

Compound 4, dissociation constant: 18.2 nM
Estimate against measurement, compound 4: 27-fold (1.44 log units) above; the measured number lies below the stated range.
By their numbers in this assay, from the lowest: compound 4; then compounds 2 and 3 (each within the scatter of the next); then compound 1.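

In this assay, putting 4-methoxyphenyl in place of 5-chloro-2-methoxyphenyl on the amine nitrogen in the ring gives a 2.7-fold lower number from compound 2 to compound 4 (0.43 log units; beyond the scatter), a modest but real gain. Going by these compounds alone, this is the first direct reading of this position, and it shows that tight binding here does not depend on the chlorine or on the methoxy placement of compound 2. Nothing shown explains why the number falls. On these data alone, the swap removes the chlorine and moves the methoxy group together, so their separate shares stay open. Also open, as far as these compounds go, is how a plain phenyl or a 4-fluorophenyl group would compare.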